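Swapping a Methoxy Ring for a Difluoro Ring

The source may hold more compounds than are shown below. What is called first, only, known or untested is meant among the compounds shown, and "the series" means these compounds.

Of the compounds shown here, three sharing one core have been measured in a functional assay on NCI-H322M cells (Homo sapiens) for inhibition, read by sulforhodamine B assay, with a stated time of 48 h; a higher number here means a weaker inhibitor of growth, a lower number a stronger inhibitor of growth. Compound 1 `COc1cc(-c2cc(/C=C/C(=O)c3ccc(N)cc3)[nH]n2)cc(OC)c1OC` gives 5590 nM. Compound 2 `COc1ccc(C(=O)/C=C/c2cc(-c3cc(OC)c(OC)c(OC)c3)n[nH]2)cc1OC` gives 2900 nM. Compound 3 `COc1ccc(C(=O)/C=C/c2cc(-c3cc(OC)c(OC)c(OC)c3)n[nH]2)cc1` gives 4070 nM, the second highest of the three numbers, and its neighbours sit close on either side: the step of a 1.4-fold lower number from compound 1 to compound 3 (0.14 log units; within the scatter) and the step of a 1.4-fold higher number from compound 2 to compound 3 (0.15 log units; within the scatter) both stay within the scatter, as does the step of a 1.9-fold lower number from compound 1 to compound 2 (0.29 log units; within the scatter).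

Compound 4 `COc1cc(-c2cc(/C=C/C(=O)c3ccc(F)c(F)c3)[nH]n2)cc(OC)c1OC` differs from compound 3 in one place: 3,4-difluorophenyl in place of 4-methoxyphenyl on a carbonyl carbon. Among the measured compounds shown here, every measured step so far also altered the ring on that carbonyl carbon, and none of them moved the number beyond the scatter; however, none of them involved fluorine, so the present swap is not directly covered. On this basis the step of a 1.0-fold lower number from compound 3 to compound 4 (0.01 log units; within the scatter) is expected to be small, with no clear direction, in this assay. Compound 4 is therefore estimated at 4000 nM, with a range from 1500 nM to 11000 nM.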

Compound 4, concentration for total growth inhibition: > 100000 nM
Compound 4: no number, only a limit; the forecaster's own chance of this, stated with the estimate: 3%; at least 25-fold (1.39 log units) between middle value and limit.
By their numbers in this assay, from the lowest: compounds 2, 3 and 1 (each within the scatter of the next). At a limit, above all of these: compound 4.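

In this assay compound 4 has no number, only a limit: the limit of > 100000 nM in this assay, at which 1 of the 4 values shown sits. The rings 4-aminophenyl, 4-methoxyphenyl and 3,4-dimethoxyphenyl on this carbonyl carbon all stayed within the scatter of one another, yet 3,4-difluorophenyl gives an at least 24-fold higher number from compound 3 to compound 4 (1.39 log units; beyond the scatter), an at least 34-fold higher number from compound 2 to compound 4 (1.53 log units; beyond the scatter) and an at least 17-fold higher number from compound 1 to compound 4 (1.25 log units; beyond the scatter). This position is therefore not indifferent to its ring: amino and methoxy groups could stand in for each other here, but the two fluorines could not stand in for either, and the data do not tell why.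

Going by these compounds, it remains open whether the fluorines themselves matter or the loss of the methoxy and amino groups. A plain phenyl ring or a chlorophenyl ring on this carbonyl carbon would help to separate those two readings.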